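The source may hold more compounds than are shown below. What is called first, only, known or untested is meant among the compounds shown, and "the series" means these compounds.

Measured so far in a functional assay on CNE-2 cells (Homo sapiens) for cytotoxicity, read by MTT assay, with a stated time of 72 h; on this read-out higher numbers stand for weaker inhibition and lower numbers for stronger inhibition:
Compound 1 `O=C(NC(=S)NNc1ncnc2ccccc12)c1ccccc1F` gives 4610 nM.
Compound 2 `COc1cc2ncnc(NNC(=S)NC(=O)c3ccccc3F)c2cc1OC` gives 12700 nM.
Compound 3 `COc1ccccc1C(=O)NC(=S)NNc1ncnc2ccccc12` gives 15700 nM.

Among these three, compound 3 carries the highest number; its gap to compound 2 lies within the scatter, while compound 1 sits clearly below it. Compound 4 `O=C(NC(=S)NNc1ncnc2ccccc12)c1ccc(F)cc1` differs from compound 3 by 4-fluorophenyl in place of 2-methoxyphenyl on a carbonyl carbon. Among the measured compounds shown here, one measured step bears on this exchange, running in the opposite direction: a 3.4-fold higher number from compound 1 to compound 3 (0.53 log units; beyond the scatter). Because that earlier step was a 3.4-fold higher number from compound 1 to compound 3 (0.53 log units; beyond the scatter), a partial reversal is expected here, though not an exact one, since the fluorine enters as 4-fluorophenyl. Compound 4 is therefore expected to show a 2.4-fold lower number from compound 3 to compound 4 (0.38 log units; beyond the scatter). The estimate for compound 4 is 6500 nM, with a range from 2500 nM to 16000 nM.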

Compound 4, half-maximal inhibitory concentration: 2840 nM
Beside the measured number, compound 4's estimate is 2.3-fold (0.36 log units) above it; the measured number falls inside the stated range.
By their numbers in this assay, from the lowest: compounds 4 and 1 (each within the scatter of the next); then compounds 2 and 3 (each within the scatter of the next).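

In this assay the exchange on the carbonyl carbon gives a 5.5-fold lower number from compound 3 to compound 4 (0.74 log units; beyond the scatter), so compound 4, like compound 1, sits clearly below the 2-methoxyphenyl compound. Moving from 2-fluorophenyl to 4-fluorophenyl gives a 1.6-fold lower number from compound 1 to compound 4 (0.21 log units; within the scatter), so these two fluorophenyl groups cannot be told apart here. Nothing available explains these results.

Still open, on these data alone, is whether an amine or a carboxylic acid on the phenyl ring would give a similar number. As far as these compounds go, it is also open whether 4-fluorophenyl would give a similar number on the core of compound 2.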